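Five-membered rings on the shared core: an estimate for compound 4

This account rests on a few compounds, and the source may have more. Where it says the series, first, only, none or still open, it means among the compounds named here.

Compound 1, `c1ccc(-c2ccncc2)c(OCC2=NCCN2)c1`, in a functional assay for activation of Alpha-1B adrenergic receptor (Homo sapiens), read by calcium flux (a lower number here means that less compound is needed, a higher number that more compound is needed for the effect), gives < 100000 nM, which is a limit of the assay.
Compound 2, `c1csc(-c2ccccc2OCC2=NCCN2)c1`, in this assay gives 3.98 nM.
Compound 3, `c1ccc(-c2ncc[nH]2)c(OCC2=NCCN2)c1`, in this assay gives < 100000 nM, again a limit of the assay.

Compound 3 therefore stands only at a limit, and so does compound 1 (the limit of < 100000 nM in this assay, at which 2 of the 3 values shown sit); compound 2 alone has a number. The three measured steps, a step that the limit leaves unreadable from compound 1 to compound 2, a step that the two limits leave unreadable from compound 1 to compound 3 and a step that the limit leaves unreadable from compound 2 to compound 3, are all left unreadable by these limits, so none of them gives a size that could be carried over.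

Compound 4, `Cn1nccc1-c1ccccc1OCC1=NCCN1`, differs from compound 3 as follows: 1-methyl-1H-pyrazol-5-yl in place of 1H-imidazol-2-yl on an aromatic carbon. No readable step bears on this change. The expectation rests only on the spread of the measured values: compound 2 shows that a five-membered ring at this carbon can give a low number, while compound 3 shows only a limit. Compound 4 is therefore estimated at 300 nM in this assay, within a wide range from 10 nM to 20000 nM. The step this estimate means, a step that the limit leaves unreadable from compound 3 to compound 4, is expected to be unreadable in size, as compound 3 is a limit.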

Compound 4, half-maximal effective concentration: < 100000 nM
Compound 4: only a limit was reported; the forecaster's own chance of this, stated with the estimate: 25%; the middle value does not contradict the limit.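

For the compounds shown here, compound 4 sits at a limit of the assay, as do compound 1 and compound 3, so no step from compound 1, compound 2 or compound 3 to compound 4 can be read in size: the limit of < 100000 nM in this assay, at which 3 of the 4 values shown sit. The compounds shown leave open how far compound 1, compound 3 and compound 4 lie from compound 2.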